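Replacing the phenyl group of compound 3

The source may hold more compounds than are shown below. What is called first, only, known or untested is meant among the compounds shown, and "the series" means these compounds.

Compound 1 (`COc1ccc(-c2nc3cnccn3c2Nc2cc(OC)c(OC)c(OC)c2)cc1O`), compound 2 (`COc1ccc(-c2nc3cnccn3c2Nc2cc(OC)c(OC)c(OC)c2)cc1`) and compound 3 (`COc1cc(-c2nc3cnccn3c2Nc2cc(OC)c(OC)c(OC)c2)cc(OC)c1O`) share one core and differ only in the substituted phenyl group it carries. In an ADME assay on Vero cells (Chlorocebus sabaeus) for cytotoxicity, read by MTT assay (on this read-out higher numbers stand for lower toxicity in this test and lower numbers for higher toxicity in this test), compound 1 gives 50000 nM, compound 2 gives 75000 nM and compound 3 gives 62000 nM. On these numbers compound 3 cannot be told apart from the other two: a 1.2-fold higher number from compound 1 to compound 3 (0.09 log units; within the scatter) and a 1.2-fold lower number from compound 2 to compound 3 (0.08 log units; within the scatter). The remaining step, a 1.5-fold higher number from compound 1 to compound 2 (0.18 log units; within the scatter), is no larger in kind.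

Compound 4 (`COc1cc(Nc2c(C3C=Nc4ccccc43)nc3cnccn23)cc(OC)c1OC`) changes the same place more deeply: a group of 9 heavy atoms (8 carbon, 1 nitrogen; one five-membered non-aromatic ring with 1 hetero atom, one six-membered aromatic ring of carbon only) in place of a group of 11 heavy atoms (8 carbon, 3 oxygen; one six-membered aromatic ring of carbon only), on an aromatic carbon. The site is an aromatic carbon of the shared core. The two steps into compound 3 bear on this most directly, since both exchange the group at that site, yet each only swaps one substituted phenyl group for another. Within the data shown here, no measured compound shows what the new group does, so they guide only weakly. Resting on compound 3 at 62000 nM, no step beyond the scatter is expected in this assay, though a real shift cannot be excluded. The estimated change is a 1.4-fold lower number from compound 3 to compound 4 (0.14 log units; within the scatter). For compound 4 the expected value is 45000 nM, with an estimated range from 15000 nM to 100000 nM.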

Compound 4, concentration lethal to 50% of the cells: 70000 nM
The estimate for compound 4 lay 1.6-fold (0.19 log units) below the measured number, within the range that was stated.
By their numbers in this assay, from the lowest: compounds 1, 3, 4 and 2 (each within the scatter of the next).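

In this assay, among these compounds, the first group at this site without a substituted phenyl ring, with one five-membered non-aromatic ring holding 1 hetero atom and one six-membered aromatic ring of carbon only, cannot be told apart from any of the three phenyl-bearing compounds: a 1.1-fold higher number from compound 3 to compound 4 (0.05 log units; within the scatter), a 1.1-fold lower number from compound 2 to compound 4 (0.03 log units; within the scatter) and a 1.4-fold higher number from compound 1 to compound 4 (0.15 log units; within the scatter). The earlier compounds shown here varied only the substituents on a phenyl group, whereas this result shows that on this aromatic carbon of the shared core the read-out also stays within the scatter when the ring system itself changes and the group carries 0 hydrogen-bond donors and 1 hydrogen-bond acceptor, against 1 donor and 3 acceptors in the 4-hydroxy-3,5-dimethoxyphenyl group it replaces. No measurement shown here offers an explanation for this result.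

All four groups at this site contain a six-membered aromatic ring of carbon only, so the compounds shown leave open what a primary amine, a carboxylic acid or a longer alkyl chain there would do to the number. They also leave open whether the read-out would stay as flat with a change elsewhere on the shared core.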